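Methoxy in place of chloro on compound 2

The compounds below may be only part of what the source reports. "The series", "measured", "known", "first", "only" and "open" are said of these compounds alone.

Of the compounds shown here, three of a shared core have been measured so far in a functional assay on 786-0 cells (Homo sapiens); a lower number here means a stronger inhibitor of growth, a higher number a weaker inhibitor of growth. Compound 2 `Cc1cc(C)c2c(O)cc(-c3ccc(Cl)cc3)nc2n1` gives 21400 nM and stands second highest of the three numbers. Its nearest neighbour is compound 1 `COc1ccccc1-c1cc(O)c2cc(C)cnc2n1`, which gives 41700 nM in this assay, a number within the scatter of compound 2. Compound 3 `COc1cccc(-c2cc(O)c3c(C)ccnc3n2)c1` is the furthest from it, giving 51.3 nM in this assay, a step beyond the scatter.

The next compound, compound 4 `COc1ccc(-c2cc(O)c3c(C)cc(C)nc3n2)cc1`, has not yet been measured. It differs from compound 2 by methoxy in place of chloro on an aromatic carbon, the place being an aromatic carbon of a six-membered aromatic ring of carbon only, para to a large group.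

Going by the values given here, no step between measured compounds with this one change exists. Compound 3 shows that a methoxy-bearing ring can sit on a potent compound, but its core differs in more than one place from compound 2. Compound 4 is therefore expected to move by a 1.8-fold lower number from compound 2 to compound 4 (0.25 log units; within the scatter), a modest step toward a lower number, with wide uncertainty. Compound 4 is estimated at 12000 nM, within 2000 nM to 60000 nM.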

Compound 4, concentration for 50% growth inhibition: 58900 nM
Compound 4: middle estimate off by 4.9-fold (0.69 log units), on the low side; the range from low to high includes it.
By their numbers in this assay, from the lowest: compound 3; then compounds 2, 1 and 4 (each within the scatter of the next, the first and the last beyond it).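

In this assay, going by these compounds alone, the change of chloro to methoxy on an aromatic carbon, para to a large group, gives a 2.8-fold higher number from compound 2 to compound 4 (0.44 log units; beyond the scatter) as the first step in this set that can be read at a single place. It shows that, at this position on this core, methoxy brings no gain in growth inhibition over chloro and instead moves the number modestly upward, even though it adds one hydrogen-bond acceptor where chloro has none. Nothing measured here accounts for this step.

Going by these compounds, whether an amine, a hydroxyl or a carboxylic acid at this same place would lower the number remains open. Compound 3 differs from compound 4 in more than one place, so the compounds shown do not tell which of those differences goes with its far lower number.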